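The source may report more compounds than this note shows. Statements on the series, on what has been measured and on what is new or still open speak of the compounds shown alone.

Measured in a physicochemical assay for solubility, in phosphate buffer, at pH 7.4; a higher number here means a more soluble compound, a lower number a less soluble compound:
- compound 1 `CC(=O)N[C@@H]1CCC[C@H](C(=O)Nc2cc(-c3cnn4c3CN(C)CC4)c(Cl)cn2)C1`: 870000 nM
- compound 2 `CC(=O)N[C@@H]1CCC[C@H](C(=O)Nc2cc(-c3cnn4c3CC(C)(C)C4)ccn2)C1`: 970000 nM

Compound 2 stands level with compound 1, as the two values lie within the scatter of each other. Compound 3 `CC(=O)N[C@@H]1CCC[C@H](C(=O)Nc2cc(-c3cnn4c3CC(C)(C)C4)c(Cl)cn2)C1` differs from compound 2 by chloro in place of hydrogen on an aromatic carbon. For the measured compounds named here, no measured pair isolates this change. Compound 1 also carries a chloro and gives 870000 nM, so only a modest fall in this assay is expected, slightly beyond the scatter. The estimated change is a 1.8-fold lower number from compound 2 to compound 3 (0.25 log units; within the scatter). For compound 3 the expected value is 550000 nM, with an estimated range of 200000 nM to 1000000 nM.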

Compound 3, solubility: 150000 nM
The estimate for compound 3 lay 3.7-fold (0.56 log units) above the measured number; measured number below the stated range.
By their numbers in this assay, from the lowest: compound 3; then compounds 1 and 2 (each within the scatter of the next).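

On the shared core, chloro in place of hydrogen on an aromatic carbon gives a 6.5-fold lower number from compound 2 to compound 3 (0.81 log units; beyond the scatter) in this assay, so this position is not neutral for this read-out when the group with the two methyls is held fixed. With the chloro held in place, the change of fused group gives a 5.8-fold lower number from compound 1 to compound 3 (0.76 log units; beyond the scatter), so the group on that aromatic carbon also moves the number.

As far as these compounds go, how a fluoro or a methyl at this position compares with chloro stays open, as does the size of the chloro step on the fused group of compound 1. No measurement at hand accounts for either step.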